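Triazole thioether series: isopropyl to phenyl on ring nitrogen

This account rests on a few compounds, and the source may have more. Where it says the series, first, only, none or still open, it means among the compounds named here.

Compound 1 `CC(C)n1c(S)nnc1Sc1nnc(-c2ccccc2)n1-c1ccccc1` has no result in a functional assay on HT-29 cells (Homo sapiens) for inhibition, read by MTT assay, with a stated time of 48 h; on this read-out higher numbers stand for weaker inhibition and lower numbers for stronger inhibition: for compound 1 the entry is "not determined" (no result reported), so it gives no number to stand on. Among the compounds with values here, the one measured member, compound 2 `Sc1nnc(CSc2nnc(-c3ccccc3)n2-c2ccccc2)n1-c1ccc(Cl)cc1`, gives 36600 nM in this assay, a weak value. Compound 3 `Sc1nnc(Sc2nnc(-c3ccccc3)n2-c2ccccc2)n1-c1ccccc1` is the analogue of compound 1 that carries phenyl in place of isopropyl on an aromatic nitrogen. Within the data shown here, with no measured pair that isolates this change, no step size can be read from the data, and the expectation for this assay is a result in the same weak region as compound 2 rather than a shift beyond the scatter. Compound 3 is therefore expected near 30000 nM, estimated within 8000 nM to 100000 nM.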

Compound 3, half-maximal inhibitory concentration: 28300 nM
Compound 3: middle estimate off by 1.1-fold (0.03 log units), on the high side; the range from low to high includes it.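

In this assay no step can be read between compound 1 and compound 3. The compounds shown leave open what phenyl in place of isopropyl on an aromatic nitrogen does to this read-out. No evidence bearing on the result is available.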